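Swapping an isopropoxy for fluoro on the aryl ring

This account rests on a few compounds, and the source may have more. Where it says the series, first, only, none or still open, it means among the compounds named here.

Measured so far:
- compound 1, `C[C@@H]1CN(c2cccc(NS(=O)(=O)c3ccc(-c4ccccn4)s3)c2)C[C@H](C)N1`: 39.8 nM
- compound 2, `COc1ccc(N2C[C@@H](C)N[C@@H](C)C2)cc1NS(=O)(=O)c1ccc(-c2ccccn2)s1`: 10 nM
- compound 3, `CC(C)Oc1ccc(N2C[C@@H](C)N[C@@H](C)C2)cc1NS(=O)(=O)c1ccc(-c2ccccn2)s1`: 100 nM

All three compounds were tested in a functional assay for agonist activity at growth hormone secretagogue receptor type 1 (Homo sapiens), read by FLIPR; a higher number here means that more compound is needed for the effect, a lower number that less compound is needed. Compound 3 gives the highest number of the three, so the most compound is needed for the effect: compound 1 sits nearer to it, compound 2 furthest away.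

Compound 4, `C[C@@H]1CN(c2ccc(F)c(NS(=O)(=O)c3ccc(-c4ccccn4)s3)c2)C[C@H](C)N1`, has not yet been measured. It differs from compound 3 in one place: fluoro in place of isopropoxy on an aromatic carbon, on an aromatic carbon of a six-membered aromatic ring of carbon only.

For the measured compounds named here, three measured steps bear on this. The step of a 2.5-fold higher number from compound 1 to compound 3 (0.40 log units; beyond the scatter) shows that putting isopropoxy where hydrogen was raised the number. The step of a 10-fold higher number from compound 2 to compound 3 (1.00 log units; beyond the scatter) shows that growing methoxy to isopropoxy raised it further. The step of a 4.0-fold lower number from compound 1 to compound 2 (0.60 log units; beyond the scatter) shows that methoxy in place of hydrogen lowered it. Fluoro is a single-atom group, closer in size to the hydrogen of compound 1 than to either alkoxy group, so a step downward, back toward the level of compound 1, is expected: a 2.9-fold lower number from compound 3 to compound 4 (0.46 log units; beyond the scatter).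

Compound 4 is therefore estimated to give 35 nM in this assay, with a range from 10 nM to 120 nM.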

Compound 4, half-maximal effective concentration: 100 nM
The estimate for compound 4 lay 2.9-fold (0.46 log units) below the measured number, within the range that was stated.
By their numbers in this assay, from the lowest: compound 2; then compound 1; then compounds 3 and 4 (each within the scatter of the next).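

In this assay the change of isopropoxy to fluoro on this aromatic carbon gives no change at the digits printed from compound 3 to compound 4 (within the scatter) here, so a group of 1 heavy atom and a group of 4 heavy atoms cannot be told apart, and group size alone does not order the substituents at this position. Fluoro does not share the lower number seen with methoxy, as a 10-fold higher number from compound 2 to compound 4 (1.00 log units; beyond the scatter) and a 2.5-fold higher number from compound 1 to compound 4 (0.40 log units; beyond the scatter) both show, which leaves methoxy as the only one of the three groups that improves on the hydrogen of compound 1, while fluoro and isopropoxy both raise the number. No measurement at hand accounts for this pattern.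

The compounds shown leave open whether the low number belongs to methoxy alone or also to close relatives such as ethoxy, hydroxyl or methylthio, which would show how narrow the preference at this position is. They also leave open how chloro, another single-atom group, or a small amine would behave on this same carbon, and whether either would sit with fluoro or with methoxy.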